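Replacing the amine-bearing ring arm with a propyl-pyrazole

A few compounds are considered here, and "the series" means these few. Any claim that something is new, unique, unknown or untested is made for them only; others in the source may bear on it.

Measured compounds:
Compound 1 `CCNC(=O)c1noc(-c2cc(C(C)C)c(O)cc2O)c1-c1cc(CNCCO)no1`: 111 nM
Compound 2 `CCCN(CCC)Cc1cc(-c2c(C(=O)NCC)noc2-c2cc(C(C)C)c(O)cc2O)on1`: 183 nM
Compound 3 `CCNC(=O)c1noc(-c2cc(C(C)C)c(O)cc2O)c1-c1cc(CN2CCN(C)CC2)no1`: 340 nM

In a functional assay on HCT-116 cells (Homo sapiens) for inhibition (a higher number here means a weaker inhibitor, a lower number a stronger inhibitor), compound 1 gives 111 nM, the lowest of the three numbers. Its nearest neighbour is compound 2, with a 1.6-fold higher number from compound 1 to compound 2 (0.22 log units; within the scatter), and its furthest is compound 3, with a 3.1-fold higher number from compound 1 to compound 3 (0.49 log units; beyond the scatter). Compound 4 `CCCn1ccc(-c2c(C(=O)NCC)noc2-c2cc(C(C)C)c(O)cc2O)n1` has not yet been measured. It differs from compound 1 by 1-propyl-1H-pyrazol-3-yl in place of 3-(((2-hydroxyethyl)amino)methyl)-1,2-oxazol-5-yl on an aromatic carbon.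

The two measured steps from compound 1 each swap only the amine at the end of the side arm, and they moved the number little or modestly. For the measured compounds named here, compound 4 goes further: the whole 3-(((2-hydroxyethyl)amino)methyl)-1,2-oxazol-5-yl group leaves and a 1-propyl-1H-pyrazol-3-yl group enters, so no measured step covers this change directly. Since every variation of that arm so far gave a higher number, compound 4 is expected to give a higher number as well, with a step of about a 3.6-fold higher number from compound 1 to compound 4 (0.56 log units; beyond the scatter). Compound 4 is therefore estimated at 400 nM, in a range from 100 nM to 1600 nM.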

Compound 4, half-maximal inhibitory concentration: 49 nM
Estimate against measurement, compound 4: 8.2-fold (0.91 log units) above; measured number below the stated range.
By their numbers in this assay, from the lowest: compound 4; then compounds 1, 2 and 3 (each within the scatter of the next, the first and the last beyond it).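

In this assay the whole arm can be exchanged without losing inhibition: 1-propyl-1H-pyrazol-3-yl in place of 3-(((2-hydroxyethyl)amino)methyl)-1,2-oxazol-5-yl gives a 2.3-fold lower number from compound 1 to compound 4 (0.36 log units; beyond the scatter) and so reverses the direction of every earlier change at this position. The earlier compounds shown here varied only the amine at the end of the arm, whereas compound 4 shows that inhibition in these cells does not depend on having that amine or the hydroxyl group, since the entering group has 0 hydrogen-bond donors against 2 in the group that leaves. No measurement shown here accounts for the lower number.

Ring and side chain changed together, so the compounds shown cannot separate the contribution of the pyrazole ring from that of the propyl chain. As far as these compounds go, how a butyl chain or a dimethylamino group on the pyrazole would behave remains open.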